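Amino substitution in a thienyl nucleoside series

The source may report more compounds than this note shows. Statements on the series, on what has been measured and on what is new or still open speak of the compounds shown alone.

Measured compounds in a functional assay on HCT-116 cells (Homo sapiens), read by MTT assay, with a stated time of 72 h; a higher number here means a weaker inhibitor, a lower number a stronger inhibitor:
- compound 1 `COc1ncnc2c1c(-c1ccsc1)cn2[C@@H]1O[C@H](CO)[C@@H](O)[C@H]1O` gives 120 nM
- compound 2 `COc1nc(N)nc2c1c(-c1ccsc1)cn2[C@@H]1O[C@H](CO)[C@@H](O)[C@H]1O` gives > 20000 nM, a limit of the assay rather than a number
- compound 3 `COc1ncnc2c1c(-c1cccs1)cn2[C@@H]1O[C@H](CO)[C@@H](O)[C@H]1O` gives 80 nM

Compound 1 and compound 3 share a core and differ only in the thienyl group, (thiophen-2-yl in place of thiophen-3-yl on an aromatic carbon). The step of a 1.5-fold lower number from compound 1 to compound 3 (0.18 log units; within the scatter) is within the scatter, so the two are treated as equivalent in this assay. The change of interest is the added amino group, (amino in place of hydrogen on an aromatic carbon), which gives an at least 160-fold higher number from compound 1 to compound 2 (2.22 log units; beyond the scatter). The size of that step is bounded by the limit of > 20000 nM in this assay, at which 1 of the 3 values shown sits.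

Compound 4 `COc1nc(N)nc2c1c(-c1cccs1)cn2[C@@H]1O[C@H](CO)[C@@H](O)[C@H]1O` has not yet been measured in this assay. It carries the same change relative to compound 3, (amino in place of hydrogen on an aromatic carbon), at a place described in identical words to the change from compound 1 to compound 2. The expectation for compound 4 is a step of a 310-fold higher number from compound 3 to compound 4 (2.49 log units; beyond the scatter), expected because the same change gave an at least 160-fold higher number from compound 1 to compound 2 (2.22 log units; beyond the scatter). Compound 4 is estimated at 25000 nM, with a range from 8000 nM to 80000 nM, and a high chance that only a limit is returned.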

Compound 4, half-maximal inhibitory concentration: > 20000 nM
Compound 4: no number, only a limit; the forecaster's own chance of this, stated with the estimate: 75%; the middle value is on the limit's open side.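

In this assay, amino in place of hydrogen on an aromatic carbon gives an at least 250-fold higher number from compound 3 to compound 4 (2.39 log units; beyond the scatter), so the large rise seen on the core of compound 1 also appears on the core of compound 3. The direction is therefore shared by the two thienyl cores, but the size of the step cannot be compared between them: the same change on two cores in this assay, an at least 160-fold higher number (2.22 log units; beyond the scatter) from compound 1 to compound 2 and an at least 250-fold higher number (2.39 log units; beyond the scatter) from compound 3 to compound 4; the limit leaves it open whether they differ Compound 2 and compound 4 each return only a limit, so the step between them cannot be read and the effect of the thienyl change on the amino-bearing core remains unknown: the limit of > 20000 nM in this assay, at which 2 of the 4 values shown sit.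

The compounds shown do not tell whether the loss is specific to amino or would also follow from another group on the aromatic carbon between two ring nitrogen atoms, such as methyl, fluorine or hydroxyl. As far as these compounds go, it also remains open whether the amino step would carry over to a core with a group other than methoxy, such as a methylamino group, in the methoxy position.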